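This account rests on a few compounds, and the source may have more. Where it says the series, first, only, none or still open, it means among the compounds named here.

Compound 3 `N#Cc1ccc(-n2ccc3ccncc32)cc1` gives 94% in an assay on isolated protein for inhibition of Aromatase (Homo sapiens), read by fluorescence, tested at 1 uM; on this read-out higher numbers stand for more inhibition at the one concentration tested (going by the name of the read-out) and lower numbers for less inhibition. Among the three compounds measured it stands second highest. Compound 1 `N#Cc1ccc(-n2ccc3ccncc32)cc1Oc1ccccc1` gives 97% in this assay, and a number 3 percentage points lower from compound 1 to compound 3 (within the scatter) lies within the scatter. Compound 2 `Ic1ccc(-n2ccc3ccncc32)cc1` gives 26% in this assay, and a number 68 percentage points higher from compound 2 to compound 3 (beyond the scatter) is a large step beyond the scatter. Compound 4 `NC(=O)c1ccc(-n2ccc3ccncc32)cc1` differs from compound 3 as follows: carbamoyl in place of cyano on an aromatic carbon. Among the compounds with values here, of the measured steps only a number 68 percentage points higher from compound 2 to compound 3 (beyond the scatter) bears on the same aromatic carbon, and it was large, so this position moves the read-out strongly; carbamoyl itself has no measured pair. A moderate loss beyond the scatter is therefore expected, a number 24 percentage points lower from compound 3 to compound 4 (beyond the scatter). Compound 4 is estimated at 70%, with a range from 40% to 92%.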

Compound 4, a percentage reported as inhibition, at one concentration (the size of the read-out at that concentration, not a potency): 60%
Estimate against measurement, compound 4: 10 percentage points above, within the range that was stated.
By their numbers in this assay, from the lowest: compound 2; then compound 4; then compounds 3 and 1 (each within the scatter of the next).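

Cyano is not the only group at this aromatic carbon that retains inhibition, but the replacement tested here is not neutral: there is a number 34 percentage points lower from compound 3 to compound 4 (beyond the scatter) on exchange for carbamoyl. The number with carbamoyl is still higher than with iodo, with a number 34 percentage points higher from compound 2 to compound 4 (beyond the scatter), so the position separates three groups into three levels rather than two. Carbamoyl also brings a hydrogen-bond donor that the other two groups lack, but one compound cannot link that count to the read-out.

As far as these compounds go, how a carboxylic acid or an amine at this carbon would rank remains open, as does whether carbamoyl costs as much alongside the phenoxy group of compound 1. No available evidence accounts for the ranking of the three groups.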